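A few compounds are considered here, and "the series" means these few. Any claim that something is new, unique, unknown or untested is made for them only; others in the source may bear on it.

Compound 1 `COc1cc(/C=C/C(=O)OCCCO[N+](=O)[O-])ccc1OCCCO[N+](=O)[O-]` and compound 3 `COc1cc(/C=C/C(=O)OCCCCCCO[N+](=O)[O-])ccc1OCCCCCCO[N+](=O)[O-]` are built on cores whose difference is not broken down here. In a functional assay on Calu-1 cells (Homo sapiens) for cytotoxicity, read by resazurin assay, with a stated time of 72 h (on this read-out higher numbers stand for weaker inhibition and lower numbers for stronger inhibition), compound 1 gives 1420 nM, while compound 3 gives 27800 nM. Compound 2 `O=C(/C=C/c1ccc(OCCCCCCO[N+](=O)[O-])c(O)c1)OCCCCCCO[N+](=O)[O-]` reaches only a limit of the assay, > 50000 nM, so no number is known for it. The change from compound 3 to compound 2 is hydrogen in place of methyl on an oxygen on an aromatic ring; it gave an at least 1.7-fold higher number from compound 3 to compound 2 (0.25 log units; that floor lies within the scatter), a floor that rests on (the limit of > 50000 nM in this assay, at which 1 of the 3 values shown sits). Compound 4 `O=C(/C=C/c1ccc(OCCCO[N+](=O)[O-])c(O)c1)OCCCO[N+](=O)[O-]` differs from compound 1 by the same change, (hydrogen in place of methyl on an oxygen on an aromatic ring), at the same place. In this assay the step from compound 1 to compound 4 is expected to be a 3.2-fold higher number from compound 1 to compound 4 (0.50 log units; beyond the scatter), resting on the earlier step of an at least 1.7-fold higher number from compound 3 to compound 2 (0.25 log units; that floor lies within the scatter). Compound 4 is therefore estimated at 4500 nM, expected to fall between 1500 nM and 20000 nM.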

Compound 4, half-maximal inhibitory concentration: 12500 nM
Estimate against measurement, compound 4: 2.8-fold (0.44 log units) below; low and high end bracket the measured number.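

In this assay, the change from methoxy to hydroxy gave an 8.8-fold higher number from compound 1 to compound 4 (0.94 log units; beyond the scatter). This is a clear step on the core of compound 1, but it cannot be compared in size with the same change on the core of compound 3, since only a floor is known there: the same change on two cores in this assay, an at least 1.7-fold higher number (0.25 log units; that floor lies within the scatter) from compound 3 to compound 2 and an 8.8-fold higher number (0.94 log units; beyond the scatter) from compound 1 to compound 4; the limit leaves it open whether they differ The two cores therefore do not contradict each other, yet they do not show that the change carries over with the same size, and compound 2 gives only a limit: the limit of > 50000 nM in this assay, at which 1 of the 4 values shown sits.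

The compounds shown leave open how an ethoxy group or an amine at the same place would compare with methoxy and hydroxy. They also leave open how far the result of this change depends on the chains that differ between the two cores.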